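A few compounds are considered here, and "the series" means these few. Any claim that something is new, unique, unknown or untested is made for them only; others in the source may bear on it.

In an ADME assay on MT4 cells (Homo sapiens) for cytotoxicity, read by MTT assay (on this read-out higher numbers stand for lower toxicity in this test and lower numbers for higher toxicity in this test), three compounds built on one shared core have been measured. Compound 1 `CCCCCOc1ccc(C(=O)N(C(=S)OCCN2C(=O)c3ccccc3C2=O)c2ccc(F)cc2)cc1` reads > 100000 nM, which is a limit of the assay and not a number. Compound 2 `Cc1cccc(C(=O)N(C(=S)OCCN2C(=O)c3ccccc3C2=O)c2ccc(Cl)cc2)c1` gives 58000 nM, the higher of the two actual numbers, while compound 3 `O=C1c2ccccc2C(=O)N1CCOC(=S)N(C(=O)c1cccc([N+](=O)[O-])c1)c1ccc(Cl)cc1` gives 18000 nM. Compound 4 `O=C1c2ccccc2C(=O)N1CCOC(=S)N(C(=O)c1ccc(C(F)(F)F)cc1)c1ccc(Cl)cc1` has not yet been measured, and it carries 4-(trifluoromethyl)phenyl in place of 3-methylphenyl on a carbonyl carbon. Among the measured compounds shown here, the only measured step that bears on this is a 3.2-fold lower number from compound 2 to compound 3 (0.51 log units; beyond the scatter), a modest one, with nitro in place of methyl on an aromatic carbon. Taking compound 3 at 18000 nM as the sole guide, a similar modest drop is expected in this assay. The expected change is a 2.3-fold lower number from compound 2 to compound 4 (0.37 log units; beyond the scatter). Compound 4 is estimated at 25000 nM, with an expected range of 8000 nM to 70000 nM.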

Compound 4, half-maximal cytotoxic concentration: 10000 nM
Compound 4: the middle estimate sits 2.5-fold (0.40 log units) above what was measured, and the stated range covers the measured number.
By their numbers in this assay, from the lowest: compounds 4 and 3 (each within the scatter of the next); then compound 2. At a limit, above all of these: compound 1.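

At the carbonyl carbon, 4-(trifluoromethyl)phenyl in place of 3-methylphenyl gives a 5.8-fold lower number from compound 2 to compound 4 (0.76 log units; beyond the scatter) in this assay. With compound 3, this makes two replacements of 3-methylphenyl that lower the number, so the drop seen earlier was not confined to the nitro group. The two replacements cannot be told apart, with a 1.8-fold lower number from compound 3 to compound 4 (0.26 log units; within the scatter).

Going by these compounds, whether an amine or a carboxylic acid on this phenyl ring would also lower the number remains open. Compound 1 is a limit and not a number, so its place stays unresolved: the limit of > 100000 nM in this assay, at which 1 of the 4 values shown sits.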